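A few compounds are considered here, and "the series" means these few. Any claim that something is new, unique, unknown or untested is made for them only; others in the source may bear on it.

Compound 1 `O=C(NCCCCc1ccccc1)c1cccc(C2SCC(=O)N2c2cccc(-c3c[nH]nn3)c2)c1` gives 110 nM in a functional assay on HOS-TE85 cells (Homo sapiens) for inhibition, read by CCK-8 assay, with a stated time of 72 h; a higher number here means a weaker inhibitor, a lower number a stronger inhibitor.
Compound 2 `CC(C)(C)c1conc1N1C(=O)CSC1c1cccc(C(=O)NCCCCc2ccccc2)c1` reaches only the limit of this assay, > 1000 nM.
Compound 3 `CCN(CC)c1ccc(N2C(=O)CSC2c2cccc(C(=O)NCCCCc3ccccc3)c2)cc1` likewise stops at the limit of this assay, > 1000 nM.

Compound 3 therefore stands at a limit and not at a number; the limit of > 1000 nM in this assay, at which 2 of the 3 values shown sit, gathers two of the three values shown, so its position relative to compound 2 cannot be read, as a step that the two limits leave unreadable from compound 2 to compound 3 records. Compound 4 `COc1cc(F)ccc1N1C(=O)CSC1c1cccc(C(=O)NCCCCc2ccccc2)c1` differs from compound 3 by 4-fluoro-2-methoxyphenyl in place of 4-(diethylamino)phenyl on an amide-type nitrogen in a ring. Within the data shown here, the steps that bear on this change are those from compound 1, where the amide-type nitrogen in the ring carries the group with the five-membered aromatic ring with 3 hetero atoms: an at least 9.0-fold higher number from compound 1 to compound 2 (0.95 log units; beyond the scatter) and an at least 9.0-fold higher number from compound 1 to compound 3 (0.95 log units; beyond the scatter). Both replacements on that nitrogen moved the value to the limit. Compound 4 carries yet another group on the same nitrogen, again a six-membered aromatic ring of carbon only without the five-membered aromatic ring of compound 1, so a number near the limit is expected rather than a return toward compound 1. The step that the limit leaves unreadable from compound 3 to compound 4 is expected to be small or unreadable. Compound 4 is estimated at 1500 nM, within 400 nM to 6000 nM.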

Compound 4, half-maximal inhibitory concentration: 71.1 nM
Compound 4: middle estimate off by 21-fold (1.32 log units), on the high side, outside the stated range (below it).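

On the amide-type nitrogen in the ring, the five-membered aromatic ring with 3 hetero atoms of compound 1 proves not to be needed for activity in this assay, as 4-fluoro-2-methoxyphenyl gives a 1.5-fold lower number from compound 1 to compound 4 (0.19 log units; within the scatter). Compound 3 and compound 4 both carry one six-membered aromatic ring of carbon only, with the same counts of donors and acceptors, yet the change of substituents on that ring gives an at least 14-fold lower number from compound 3 to compound 4 (1.14 log units; beyond the scatter), and the group of compound 2 gives way with a similar result, an at least 14-fold lower number from compound 2 to compound 4 (1.14 log units; beyond the scatter). Compound 2 and compound 3 stand at a limit and not at a number, so both of these sizes are only minimum sizes and the step between those two compounds cannot be read: the limit of > 1000 nM in this assay, at which 2 of the 4 values shown sit.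

The compounds shown do not separate the methoxy from the fluoro of the new group, so it stays open how a phenyl bearing only a methoxy or only a fluorine would stand in this assay. Also open, from the compounds shown here alone, is how a plain phenyl or a 4-(dimethylamino)phenyl on the same nitrogen would compare with compound 4.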